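This account rests on a few compounds, and the source may have more. Where it says the series, first, only, none or still open, it means among the compounds named here.

The series shares the core of compound 1 `CCC(=O)NCc1ccc(C(=O)Nc2ccc(C)c(Nc3nccc(-c4cccnc4)n3)c2)cc1`. In an ADME assay on BaF3 cells (Mus musculus) for cytotoxicity, read by CellTiter-Glo and CCK-8 assay, with a stated time of 72 h (on this read-out lower numbers stand for stronger inhibition of growth and higher numbers for weaker inhibition of growth), compound 1 gives only an assay limit, > 10000 nM. Compound 2 `CCC(=O)N(CCN(C)C)Cc1ccc(C(=O)Nc2ccc(C)c(Nc3nccc(-c4cccnc4)n3)c2)cc1` likewise gives in this assay only a limit, > 10000 nM. The step that the two limits leave unreadable from compound 1 to compound 2 therefore stays unreadable, since (the limit of > 10000 nM in this assay, at which 2 of the 2 values shown sit). Compound 3 `Cc1ccc(NC(=O)c2ccc(CN(CCN(C)C)C(=O)CN(C)C)cc2)cc1Nc1nccc(-c2cccnc2)n1` differs from compound 2 by dimethylamino in place of methyl on a saturated chain carbon bound to a carbonyl carbon. For the measured compounds named here, no measured step bears readably on this change; the one step in the set sits between two limits. The expected step that the limit leaves unreadable from compound 2 to compound 3 amounts to no movement beyond the scatter. Compound 3 is thus estimated at 20000 nM, with a range from 6000 nM to 80000 nM.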

Compound 3, concentration for 50% growth inhibition: > 10000 nM
Compound 3: only a limit was reported (the forecaster's own chance of this, stated with the estimate: 75%); the middle value is on the limit's open side.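

No step can be read among compound 1, compound 2 and compound 3, because all three give only limits: the limit of > 10000 nM in this assay, at which 3 of the 3 values shown sit. On these data alone, whether any change on the shared core brings a measurable value in this assay stays open.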